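The source may report more compounds than this note shows. Statements on the series, on what has been measured and on what is new or still open speak of the compounds shown alone.

Compound 1 `Cc1nc(N)c2c(-c3ccccc3)cn([C@@H]3O[C@H](CO)[C@@H](O)[C@H]3O)c2n1`: > 20000 nM. Compound 2 `Nc1nc(N)c2c(-c3ccccc3)cn([C@@H]3O[C@H](CO)[C@@H](O)[C@H]3O)c2n1`: > 20000 nM. Compound 3 `CNc1ncnc2c1c(-c1cccs1)cn2[C@@H]1O[C@H](CO)[C@@H](O)[C@H]1O`: > 20000 nM.

In a functional assay on K562 cells (Homo sapiens), read by MTT assay, with a stated time of 72 h (a higher number here means a weaker inhibitor, a lower number a stronger inhibitor), compound 1 gives > 20000 nM, which is a limit of the assay and not a number. Compound 2 likewise gives only a limit, > 20000 nM. Compound 3 too sits at a limit, > 20000 nM. Going by the values given here, the single measured step, a step that the two limits leave unreadable from compound 1 to compound 2, therefore cannot be sized, since the limit of > 20000 nM in this assay, at which 3 of the 3 values shown sit, holds all three values. Compound 4 `Cc1nc(N)c2c(-c3ccsc3)cn([C@@H]3O[C@H](CO)[C@@H](O)[C@H]3O)c2n1` differs from compound 1 by thiophen-3-yl in place of phenyl on an aromatic carbon. Among the compounds with values here, no measured step touches this change, and every value shown sits at the same limit, so no step beyond the scatter is expected for a step that the limit leaves unreadable from compound 1 to compound 4. Compound 4 is estimated at 30000 nM, within 20000 nM to 100000 nM, most likely again reported only as a limit.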

Compound 4, half-maximal inhibitory concentration: > 20000 nM
Compound 4: a limit, no number; the forecaster's own chance of this, stated with the estimate: 85%; the middle value does not contradict the limit.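

The step from compound 1 to compound 4 cannot be read, since both values are limits of the assay: the limit of > 20000 nM in this assay, at which 4 of the 4 values shown sit. In this assay the compounds shown leave open whether any change to the shared core gives a readable number.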